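A few compounds are considered here, and "the series" means these few. Any claim that something is new, unique, unknown or untested is made for them only; others in the source may bear on it.

Measured in a functional assay on K562 cells (Homo sapiens) for cytotoxicity, in the presence of a further agent that is not named here; a higher number here means a weaker inhibitor, a lower number a stronger inhibitor:
- compound 1 `Cc1ccccc1-c1cc(-c2ccc(Cl)o2)cc(-c2ccsc2)n1`: 18400 nM
- compound 2 `Clc1ccc(-c2cc(-c3ccoc3)cc(-c3cccs3)n2)cc1`: 21100 nM
- compound 3 `Cc1ccc(-c2cc(-c3ccc(Cl)o3)cc(-c3cccs3)n2)cc1`: 21500 nM

These three numbers sit so close together that they cannot be told apart: repeated measurements of this kind vary by at least as much as the gaps between them. Compound 1 therefore stands level with compound 2 and compound 3, and none of the three can be ranked above the others.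

The next compound to be tested is compound 4 `Clc1cccc(-c2cc(-c3ccc(Cl)o3)cc(-c3ccsc3)n2)c1`. It keeps the core of compound 1 and changes a single group: 3-chlorophenyl in place of 2-methylphenyl on an aromatic carbon, next to the ring nitrogen (3-chlorophenyl in place of 2-methylphenyl on an aromatic carbon).

Within the data shown here, no two measured compounds differ in only one place, so the data hold no direct measure of such a swap. The best available guide is the narrow spread of values, from compound 1 at 18400 nM to compound 3 at 21500 nM, even though these structures differ in more than one place. On that basis, no shift beyond the scatter is expected in this assay.

The estimated step is a 1.1-fold lower number from compound 1 to compound 4 (0.03 log units; within the scatter).

For compound 4 the expected value is 17000 nM, with an estimated range from 7500 nM to 35000 nM.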

Compound 4, half-maximal inhibitory concentration: 23000 nM
For compound 4 the middle estimate is 1.4-fold (0.13 log units) below the measured one; low and high end bracket the measured number.
By their numbers in this assay, from the lowest: compounds 1, 2, 3 and 4 (each within the scatter of the next).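

In this assay, among these compounds, the swap gives the first direct reading of a change at this position, the aromatic carbon next to the ring nitrogen, and the step is a 1.3-fold higher number from compound 1 to compound 4 (0.10 log units; within the scatter) so 3-chlorophenyl and 2-methylphenyl cannot be told apart here. Among the compounds shown here, the single pair changes two things at once, the kind of substituent on the phenyl ring and where it sits on that ring, so neither can be judged alone; all that can be said is that together they produce no shift beyond the scatter, with compound 1 at 18400 nM and compound 4 at 23000 nM standing level. Nothing measured here speaks to why these two groups read alike.

Still open, as far as these compounds go, is whether any group at this position can move the number beyond the scatter, for instance a morpholine, a carboxylic acid or a longer alkyl chain in place of the substituted phenyl ring. Also open is what the 5-chlorofuran-2-yl and thiophen-3-yl groups contribute, since no pair shown changes either of them alone.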